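The compounds below may be only part of what the source reports. "The series", "measured", "known", "first", "only" and "open" are said of these compounds alone.

In a physicochemical assay for solubility, read by HPLC, measured as thermodynamic solubility, with a stated time of 4 h, at pH 6.8 (on this read-out higher numbers stand for higher solubility and lower numbers for lower solubility), compound 3 `Cc1cccc(Oc2ccc3nc(COc4cccc(C(=O)O)c4)n(C)c3c2)n1` gives 92 ug/mL, the highest of the three numbers in hand. Compound 1 `Cn1c(COc2cccc(C(=O)O)c2)nc2ccc(Oc3ccc(Cl)cn3)cc21` gives 17 ug/mL and compound 2 `Cn1c(COc2cccc(C(=O)O)c2)nc2ccc(Oc3ncccc3Cl)cc21` gives 15 ug/mL; the step of a 5.4-fold higher number from compound 1 to compound 3 (0.73 log units; beyond the scatter) and the step of a 6.1-fold higher number from compound 2 to compound 3 (0.79 log units; beyond the scatter) both lie beyond the scatter. Compound 4 `Cc1ccnc(Oc2ccc3nc(COc4cccc(C(=O)O)c4)n(C)c3c2)c1` differs from compound 3 by 4-methylpyridin-2-yl in place of 6-methylpyridin-2-yl on an oxygen on an aromatic ring. For the measured compounds named here, no measured step covers this change directly. Going by the values given here, the only step that moves a substituent around the same pyridine ring, a 1.1-fold lower number from compound 1 to compound 2 (0.05 log units; within the scatter), stayed within the scatter, so nothing seen here points to a shift beyond the scatter. Compound 4 is therefore expected to give 70 ug/mL, with a range of 25 ug/mL to 180 ug/mL. The expected step of a 1.3-fold lower number from compound 3 to compound 4 (0.12 log units; within the scatter) is estimated to fall within the scatter.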

Compound 4, solubility: 33 ug/mL
Beside the measured number, compound 4's estimate is 2.1-fold (0.33 log units) above it; low and high end bracket the measured number.
By their numbers in this assay, from the lowest: compounds 2, 1 and 4 (each within the scatter of the next, the first and the last beyond it); then compound 3.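

In this assay, where the methyl sits on the pyridine ring does matter at this position, with 4-methylpyridin-2-yl in place of 6-methylpyridin-2-yl giving a 2.8-fold lower number from compound 3 to compound 4 (0.45 log units; beyond the scatter). Against the chlorinated compounds, the new group shows a 2.2-fold higher number from compound 2 to compound 4 (0.34 log units; beyond the scatter), but only a 1.9-fold higher number from compound 1 to compound 4 (0.29 log units; within the scatter), so the large gap seen for compound 3 does not extend to every methyl placement. Nothing in hand explains why the two methyl placements differ. From the compounds shown here alone, whether a methoxy group or an amine in place of the methyl would keep this order remains open.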